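This account rests on a few compounds, and the source may have more. Where it says the series, first, only, none or still open, it means among the compounds named here.

Compound 1 `CC(C)(C)OC(=O)N1CCC(O[C@H]2CC[C@H](Oc3ccc(S(C)(=O)=O)cc3)CC2)CC1` gives 115% in a functional assay on isolated protein for agonist activity at Glucose-dependent insulinotropic receptor (Homo sapiens), read by HTRF and cAMP accumulation (on this read-out higher numbers stand for larger maximal responses and lower numbers for smaller maximal responses), compound 2 `CC(C)(C)OC(=O)N1CCC(O[C@H]2CC[C@H](Oc3ccc(S(C)(=O)=O)cn3)CC2)CC1` gives 111%, and the step of a number 4 percentage points lower from compound 1 to compound 2 (within the scatter) stays within the scatter. Compound 3 `CC(C)OC(=O)N1CCC(O[C@H]2CC[C@H](Oc3cnc(S(C)(=O)=O)cn3)CC2)CC1` gives 110%; its number is the lowest of the three, yet the gaps to compound 2 and to compound 1 both lie within the scatter, so no order among them can be claimed. Compound 4 `CS(=O)(=O)c1cnc(O[C@H]2CC[C@H](OC3CCN(CC4(C(F)(F)F)CC4)CC3)CC2)cn1` differs from compound 3 by (1-(trifluoromethyl)cyclopropyl)methyl in place of isopropoxycarbonyl on an amine nitrogen in a ring. Within the data shown here, no measured step touches the amine nitrogen of the ring, so the only step known, from compound 1 to compound 2, does not bear on this change. Compound 3 therefore serves as the anchor, and compound 4 is expected to give 108%, between 85% and 125%, with an expected step of a number 2 percentage points lower from compound 3 to compound 4 (within the scatter).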

Compound 4, largest response reached (Emax), in percent of the reference or control that the assay uses: 116%
Estimate against measurement, compound 4: 8 percentage points below, within the range that was stated.
By their numbers in this assay, from the lowest: compounds 3, 2, 1 and 4 (each within the scatter of the next).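

In this assay, putting (1-(trifluoromethyl)cyclopropyl)methyl in place of isopropoxycarbonyl on the amine nitrogen in the ring gives a number 6 percentage points higher from compound 3 to compound 4 (within the scatter), the only step shown at this position. The group that leaves has a double bond outside aromatic rings and hydrogen-bond acceptors and the group that enters has neither, yet the maximal response stays within the scatter. Nothing at hand bears on the reason for this result. As far as these compounds go, what a benzyl group or a longer alkyl chain on this nitrogen would give stays open, as does the response of the free secondary amine.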